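Pyridinyl to thiophenyl swap in the hydroxyphenyl series

A few compounds are considered here, and "the series" means these few. Any claim that something is new, unique, unknown or untested is made for them only; others in the source may bear on it.

Working notes on a small set sharing one core. Compound 1 `Oc1cccc(-c2cc(-c3cccnc3)nc(-c3cccc(Cl)c3)c2)c1` carries a 3-hydroxyphenyl group, a pyridin-3-yl group and a 3-chlorophenyl group on that core. In a functional assay on DU-145 cells (Homo sapiens) for cytotoxicity, read by CCK-8 assay and cell counting, with a stated time of 2 days (on this read-out lower numbers stand for stronger inhibition and higher numbers for weaker inhibition), compound 1 stands at "not determined" (no result reported); no number is available for it. Compound 2 `Oc1cccc(-c2cc(-c3cccnc3)nc(-c3ccccc3Cl)c2)c1` likewise has no result, standing at "not determined" (no result reported) in this assay. Going by the values given here, the only number in the set belongs to compound 3 `Oc1ccc(-c2cc(-c3cccnc3)nc(-c3cccc(Cl)c3)c2)cc1`, which in this assay gives 22900 nM, a weak effect. Among the compounds with values here, compound 3 and compound 1 differ in where the hydroxyl sits on the phenyl group, and no step between them is computed, so the two values show only that compound 3 is weak and compound 1 is unknown.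

Compound 4 `Oc1cccc(-c2cc(-c3ccsc3)nc(-c3cccc(Cl)c3)c2)c1` is the next case. It differs from compound 1 by thiophen-3-yl in place of pyridin-3-yl on an aromatic carbon. Within the data shown here, with no measured step in this assay for this change, no direction can be stated; the expected size of the step is none beyond the scatter, but that is a guess with nothing behind it. With compound 3 at 22900 nM as the only reference, compound 4 is expected in this assay at about 20000 nM, within a range from 4000 nM to 100000 nM.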

Compound 4, half-maximal inhibitory concentration: 3330 nM
Beside the measured number, compound 4's estimate is 6.0-fold (0.78 log units) above it, and the stated range ends above it.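

In this assay compound 4 gives 3330 nM and compound 1 stands at "not determined" (no result reported) with no number, so no step can be read between them. The compounds shown leave open whether thiophen-3-yl in place of pyridin-3-yl changes the value in either direction. Nothing available explains the value of compound 4.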